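Swapping the acid for a dimethylamide on a cyclopropane

A few compounds are considered here, and "the series" means these few. Any claim that something is new, unique, unknown or untested is made for them only; others in the source may bear on it.

Compound 1 `Cc1nc(-c2ccc(C(F)(F)F)cc2)sc1CNc1ccc(CC(=O)O)cc1` gives 18% in a functional assay on CHO cells for agonist activity at Free fatty acid receptor 1 (Homo sapiens), read by a luciferase reporter; a lower number here means a smaller maximal response, a higher number a larger maximal response; compound 2 `Cc1nc(-c2ccc(C(F)(F)F)cc2)sc1CNc1ccc(OCC(=O)O)cc1` gives 100%.

Compound 2 stands highest of the two numbers; its nearest neighbour is compound 1, which lies a number 82 percentage points higher from compound 1 to compound 2 (beyond the scatter) below it. Compound 3 `Cc1nc(-c2ccc(C(F)(F)F)cc2)sc1CNc1ccc([C@H]2C[C@@H]2C(=O)N(C)C)cc1` differs from compound 2 by 2-(dimethylcarbamoyl)cyclopropyl in place of carboxymethoxy on an aromatic carbon. For the measured compounds named here, no measured step involves the entering group, so the only guide is the large step of a number 82 percentage points higher from compound 1 to compound 2 (beyond the scatter), which shows that changes at this aromatic carbon can move the maximal response far. Compound 3 is therefore expected to fall, with an estimated step of a number 50 percentage points lower from compound 2 to compound 3 (beyond the scatter), to about 50% (range 10% to 100%).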

Compound 3, largest response reached (reported as percent of maximum), in percent of the reference or control that the assay uses: 49%
Estimate against measurement, compound 3: 1 percentage points above, within the range that was stated.
By their numbers in this assay, from the lowest: compound 1; then compound 3; then compound 2.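

At this aromatic carbon, a carboxylic acid is not required for a response: in this assay the value is a number 51 percentage points lower from compound 2 to compound 3 (beyond the scatter), yet it is also a number 31 percentage points higher from compound 1 to compound 3 (beyond the scatter). The amide compound 3 thus lies between the two acids, so the presence of an acid alone does not set the order among these compounds. No evidence is available to explain this result.

The compounds shown leave open how a carboxylic acid on the same cyclopropane would compare with the dimethylamide. They also leave open whether a primary amide would behave like the dimethylamide, and what the other stereoisomers of the cyclopropane would give.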